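Methoxy to methyl on compound 1

The compounds below may be only part of what the source reports. "The series", "measured", "known", "first", "only" and "open" are said of these compounds alone.

Measured so far in an ADME assay on HepG2 2.2.15 cells (Homo sapiens) for cytotoxicity, read by MTT assay, with stated times of 48 h and 9 days; a higher number here means that more compound is tolerated, a lower number that less compound is tolerated:
Compound 1 `COc1ccc(CNC(=O)/C=C/c2coc3cc(O)ccc3c2=O)cc1` gives 718000 nM
Compound 2 `COc1ccc2c(=O)c(/C=C/C(=O)NCc3cccc(F)c3)coc2c1` gives 475000 nM
Compound 3 `COc1ccc(CNC(=O)/C=C/c2coc3cc(OC)ccc3c2=O)cc1` gives 43000 nM

Compound 1 and compound 2 lie within the usual scatter of each other, and both stand well above compound 3. Compound 4 `Cc1ccc(CNC(=O)/C=C/c2coc3cc(O)ccc3c2=O)cc1` is compound 1 with methyl in place of methoxy on an aromatic carbon. Within the data shown here, no measured step makes this exact swap. The closest is an 11-fold lower number from compound 2 to compound 3 (1.04 log units; beyond the scatter), which also exchanges the 4-methoxyphenyl group, so a large move cannot be ruled out. The other, a 17-fold lower number from compound 1 to compound 3 (1.22 log units; beyond the scatter), changes a different place. The expected step is a 1.2-fold lower number from compound 1 to compound 4 (0.08 log units; within the scatter), with no step beyond the scatter and no firm direction expected in this assay. Compound 4 is estimated at 600000 nM, with an expected range of 200000 nM to 1300000 nM.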

Compound 4, half-maximal cytotoxic concentration: 501000 nM
Compound 4: middle estimate off by 1.2-fold (0.08 log units), on the high side, and the stated range covers the measured number.
By their numbers in this assay, from the lowest: compound 3; then compounds 2, 4 and 1 (each within the scatter of the next).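

In this assay the change from 4-methoxyphenyl to 4-methylphenyl gives a 1.4-fold lower number from compound 1 to compound 4 (0.16 log units; within the scatter) and stays within the scatter. With the hydroxy group kept on the core, this place therefore accepts methyl for methoxy, a swap that removes one hydrogen-bond acceptor, with no readable change in the tolerated concentration. No measurement at hand explains this result.

Going by these compounds, whether an amine or a carboxylic acid would be tolerated equally at this place remains open. So does whether methyl would behave the same on the core of compound 3, which carries methoxy instead of that hydroxy group.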